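A few compounds are considered here, and "the series" means these few. Any claim that something is new, unique, unknown or untested is made for them only; others in the source may bear on it.

Measured compounds:
compound 1 `O=C(/C=C/c1ccc2c(c1)B(O)OC2)c1ccccc1` — 6100 nM
compound 2 `O=C(/C=C/c1ccc2c(c1)B(O)OC2)c1cccc(O)c1` — 6500 nM

Both numbers come from a functional assay on HCT-116 cells (Homo sapiens) for cytotoxicity, read by MTT assay, with a stated time of 48 h; on this read-out lower numbers stand for stronger inhibition and higher numbers for weaker inhibition. Compound 1 holds the lowest of the two numbers, and its nearest neighbour is compound 2, separated by a 1.1-fold higher number from compound 1 to compound 2 (0.03 log units; within the scatter); on this read-out the two compounds cannot be told apart. The only structural variation measured so far is a substituent entering the six-membered aromatic ring of carbon only that bears the carbonyl, and it leaves the number unchanged within the scatter.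

Compound 3 `COCOc1ccccc1C(=O)/C=C/c1ccc2c(c1)B(O)OC2` differs from compound 1 by methoxymethoxy in place of hydrogen on an aromatic carbon. Going by the values given here, no measured step introduces this group, so the nearest guide is the step from compound 1 to compound 2, in which a substituent entering the same ring gave a 1.1-fold higher number from compound 1 to compound 2 (0.03 log units; within the scatter). On that single precedent no shift beyond the scatter is expected in this assay for compound 3, with the caveat that the entering group is larger than the hydroxy of compound 2 and the evidence is thin. For compound 3 the expected step is a 1.1-fold higher number from compound 1 to compound 3 (0.03 log units; within the scatter). Compound 3 is therefore estimated at 6500 nM, within a range from 2800 nM to 15000 nM.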

Compound 3, half-maximal inhibitory concentration: 10200 nM
Compound 3: the middle estimate sits 1.6-fold (0.20 log units) below what was measured; the measured number falls inside the stated range.
By their numbers in this assay, from the lowest: compounds 1, 2 and 3 (each within the scatter of the next).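

In this assay, methoxymethoxy on an aromatic carbon ortho to a large group gives a 1.7-fold higher number from compound 1 to compound 3 (0.22 log units; within the scatter), so this place on the ring bearing the carbonyl accepts a group of 4 heavy atoms, with no hydrogen-bond donor, without a step beyond the scatter. Together with the hydroxy step, a 1.1-fold higher number from compound 1 to compound 2 (0.03 log units; within the scatter), this makes two substituents on that ring, and neither step leaves the scatter, so within compounds 1, 2 and 3 substitution on this ring has not yet moved the number in this assay by a readable amount. Nothing available bears on the reason for this flat response, and the size of the step for compound 3 stands without explanation.

Still open, on these data alone, is whether a free hydroxy, an amine or a carboxylic acid at this same place would also stay within the scatter of compound 1, or whether a longer ether chain would move the number beyond it. Also open, as far as these compounds go, is whether any change to the shared core or to the enone linker would shift the number in this assay more than these ring substituents do.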